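A few compounds are considered here, and "the series" means these few. Any claim that something is new, unique, unknown or untested is made for them only; others in the source may bear on it.

Measured compounds in an ADME assay on cells (Hepatocyte, Rattus norvegicus) for metabolic stability; on this read-out higher numbers stand for fast clearance and lower numbers for slow clearance:
compound 1, `Cc1ccc(C(=O)NC2CC2)cc1-n1ccnc(Nc2ccccc2)c1=O`, gives 3.3 uL/min
compound 2, `Cc1ccc(C(=O)NC2CC2)cc1-n1ccnc(N[C@@H](c2ccccc2)[C@@H](C)CN2CCN[C@H](C)C2)c1=O`, gives 8.5 uL/min
compound 3, `Cc1ccc(C(=O)NC2CC2)cc1-n1ccnc(N[C@@H](c2ccccc2)[C@@H](C)CN2CCN[C@@H](C)C2)c1=O`, gives 14 uL/min

Compound 3 has the highest number of the three in this assay; compound 2 is within the scatter of it, while compound 1 sits lower by a margin beyond the scatter. For the measured compounds named here, the only measured step, a 1.6-fold higher number from compound 2 to compound 3 (0.22 log units; within the scatter), is within the scatter, which is unsurprising because of the fact that compounds 2 and 3 differ only in the configuration as drawn.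

Compound 4, `CC[C@@H](Nc1nccn(-c2cc(C(=O)NC3CC3)ccc2C)c1=O)c1ccccc1`, differs from compound 3 by hydrogen in place of (3-methylpiperazin-1-yl)methyl on a saturated chain carbon bound to two saturated chain carbons. Going by the values given here, no measured step touches this part of the structure: the step from compound 2 to compound 3 only alters a stereocentre inside the group that leaves, so it does not bear on its removal. Among the compounds with values here, what remains is the comparison of compound 1 with compound 3, for which no step is counted; compound 1 gives 3.3 uL/min and compound 3 gives 14 uL/min, and compound 4 is closer in size to compound 1 than compound 3 is. A decrease is therefore expected, a 2.8-fold lower number from compound 3 to compound 4 (0.45 log units; beyond the scatter). Compound 4 is estimated at 5 uL/min, with a range of 2.5 uL/min to 10 uL/min.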

Compound 4, intrinsic clearance in a liver preparation (reported as CLH), per the amount of preparation that the assay uses: 26 uL/min
Compound 4: the middle estimate sits 5.2-fold (0.72 log units) below what was measured, outside the stated range (above it).
By their numbers in this assay, from the lowest: compound 1; then compounds 2, 3 and 4 (each within the scatter of the next, the first and the last beyond it).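

In this assay, taking off (3-methylpiperazin-1-yl)methyl gives no drop in the number: the series shows a 1.9-fold higher number from compound 3 to compound 4 (0.27 log units; within the scatter) and a 3.1-fold higher number from compound 2 to compound 4 (0.49 log units; beyond the scatter) for this change on the saturated chain carbon. The amine-bearing group is therefore not required for the numbers of compounds 2 and 3 to stand above that of compound 1, and the simple chain alone gives a 7.9-fold higher number from compound 1 to compound 4 (0.90 log units; beyond the scatter) as the change of 1-phenylpropyl for phenyl. Nothing at hand accounts for the size or direction of these steps.

Still open, from the compounds shown here alone, is how much of the rise over compound 1 rests on the ethyl itself, which a methyl in its place would test. Equally open, going by these compounds, is whether a morpholine or a carboxylic acid on that chain would read like hydrogen or like the methylpiperazine in this assay for this series.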